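The compounds below may be only part of what the source reports. "The series", "measured", "known", "first", "only" and "open" are said of these compounds alone.

In an assay on isolated protein for binding affinity to 5-hydroxytryptamine receptor 4 (Homo sapiens) (on this read-out higher numbers stand for weaker inhibition and lower numbers for stronger inhibition), compound 1 `CS(=O)(=O)N1CCN(CC(O)CN2CCC(CNC(=O)c3cccc4[nH]cnc34)CC2)CC1` gives 6.31 nM, while compound 2 `CCc1nc2c(C(=O)NCC3CCN(CC(O)CN4CCN(S(C)(=O)=O)CC4)CC3)cccc2[nH]1` gives 0.501 nM. Among the measured compounds shown here, the one measured step joins these two: a 13-fold lower number from compound 1 to compound 2 (1.10 log units; beyond the scatter). For the measured compounds named here, compound 2 therefore holds the lowest of the two numbers in this assay, and its only neighbour, compound 1, lies well beyond the scatter above it.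

Compound 3 `CS(=O)(=O)N1CCN(CC(O)CN2CCC(CNC(=O)c3cccc4[nH]c(C5CC5)nc34)CC2)CC1` keeps the whole of compound 2 except at the place of that earlier change, where the difference is cyclopropyl in place of ethyl on an aromatic carbon. Going by the values given here, no measured pair shows an exchange of one small carbon group for another at this position; the step from compound 1 to compound 2 only shows that filling this position with ethyl, compared with hydrogen, goes with a much lower number. Since compound 3 keeps a small carbon group there, the expectation is a step of a 1.0-fold lower number from compound 2 to compound 3 (0.00 log units; within the scatter), that is, nothing beyond the scatter. On that basis compound 3 is expected to give about 0.5 nM in this assay, within a range from 0.15 nM to 1.6 nM.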

Compound 3, inhibition constant: 0.501 nM
Beside the measured number, compound 3's estimate is 1.0-fold (0.00 log units) below it; the measured number falls inside the stated range.
By their numbers in this assay, from the lowest: compounds 2 and 3 (each within the scatter of the next); then compound 1.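

In this assay, cyclopropyl in place of ethyl on this aromatic carbon gives no change at the digits printed from compound 2 to compound 3 (within the scatter) and so shows that a group with one more carbon, closed into a three-membered ring, fits here without a measurable loss. Against hydrogen, cyclopropyl gives a 13-fold lower number from compound 1 to compound 3 (1.10 log units; beyond the scatter) and this means the large drop in the number is not tied to ethyl alone: two different small carbon groups at this place, between two ring nitrogen atoms, both go with a much lower number than hydrogen. Nothing on hand explains why these two groups behave alike here.

The compounds shown carry only hydrogen, ethyl and cyclopropyl at this place, so it remains open whether a longer chain such as butyl, or a group carrying an amine or a carboxylic acid, would keep the number this low. With ethyl and cyclopropyl within the scatter of each other, nothing yet marks how large the group can become, for example tert-butyl or phenyl, before the number rises again.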